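Fluorine moved on the aryl group: compound 2 to compound 3

This account rests on a few compounds, and the source may have more. Where it says the series, first, only, none or still open, it means among the compounds named here.

In a functional assay on MDA-MB-231 cells (Homo sapiens) for antiproliferative activity, read by MTT assay, with a stated time of 24 h (on this read-out higher numbers stand for weaker inhibition and lower numbers for stronger inhibition), compound 1 (`O=C(NNc1cccc(Cl)c1)c1cccc(NS(=O)(=O)c2cnc(O)nc2O)c1`) gives 7760 nM. Compound 2 (`O=C(NNc1ccccc1F)c1cccc(NS(=O)(=O)c2cnc(O)nc2O)c1`) gives > 20000 nM, which is a limit of the assay and not a number. Compound 3 (`O=C(NNc1ccc(F)cc1)c1cccc(NS(=O)(=O)c2cnc(O)nc2O)c1`) carries 4-fluorophenyl in place of 2-fluorophenyl on an amine nitrogen. Among the compounds with values here, the only measured step bearing on this change is an at least 2.5-fold higher number from compound 1 to compound 2 (0.41 log units; beyond the scatter), and it comes from a different exchange of groups. In this assay a modest move toward a lower number is therefore expected, though compound 3 may also stay at the limit. The expected move is an at least 1.3-fold lower number from compound 2 to compound 3 (0.12 log units; that floor lies within the scatter). For compound 3 the estimate is 15000 nM, with an expected range of 6000 nM to 40000 nM.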

Compound 3, half-maximal inhibitory concentration: > 20000 nM
Compound 3: only a limit was reported; the forecaster's own chance of this, stated with the estimate: 40%; middle value at least 1.3-fold (0.12 log units) away from the limit.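

In this assay, 4-fluorophenyl in place of 3-chlorophenyl on the amine nitrogen gives an at least 2.5-fold higher number from compound 1 to compound 3 (0.41 log units; beyond the scatter), so the second fluorophenyl compound also reads weaker than the 3-chlorophenyl compound. The step between 2-fluorophenyl and 4-fluorophenyl cannot be read, because both compounds rest at a limit: the limit of > 20000 nM in this assay, at which 2 of the 3 values shown sit.

Any real difference between these two fluorine positions therefore stays hidden. Also open, as far as these compounds go, is whether 3-fluorophenyl or 4-chlorophenyl would read like 3-chlorophenyl, which would help separate the halogen from its position on the aryl group.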